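Quinazoline acrylamides: cyanophenyl swap on the methoxy core

The source may hold more compounds than are shown below. What is called first, only, known or untested is meant among the compounds shown, and "the series" means these compounds.

Measured so far:
compound 1, `COc1ccc(/C=C/C(=O)Nc2cc3c(Nc4ccc(F)c(Cl)c4)ncnc3cc2O[C@H]2CCOC2)c(OC)c1`, 2760 nM
compound 2, `N#Cc1ccc(/C=C/C(=O)Nc2cc3c(Nc4ccc(F)c(Cl)c4)ncnc3cc2O[C@H]2CCOC2)cc1`, 36600 nM
compound 3, `COc1ccc(/C=C/C(=O)Nc2cc3c(Nc4ccc(F)c(Cl)c4)ncnc3cc2OC)c(OC)c1`, 38500 nM

In a functional assay on PC-3 cells (Homo sapiens) for cytotoxicity, read by MTT assay, with a stated time of 72 h (on this read-out lower numbers stand for stronger inhibition and higher numbers for weaker inhibition), compound 1 gives 2760 nM and is the lowest number of the three. Compound 2 differs from compound 1 by 4-cyanophenyl in place of 2,4-dimethoxyphenyl on a double-bonded chain carbon bound to a double-bonded chain carbon, and the step of a 13-fold higher number from compound 1 to compound 2 (1.12 log units; beyond the scatter). Compound 3 differs from compound 1 by methyl in place of oxolan-3-yl on an oxygen on an aromatic ring, and the step of a 14-fold higher number from compound 1 to compound 3 (1.14 log units; beyond the scatter). Compound 2 and compound 3 therefore stand within the scatter of each other.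

Compound 4, `COc1cc2ncnc(Nc3ccc(F)c(Cl)c3)c2cc1NC(=O)/C=C/c1ccc(C#N)cc1`, is not yet measured in this assay. It differs from compound 3 by 4-cyanophenyl in place of 2,4-dimethoxyphenyl on a double-bonded chain carbon bound to a double-bonded chain carbon, the same change already seen between compound 1 and compound 2, on the same place. The two cores differ by methyl in place of oxolan-3-yl on an oxygen on an aromatic ring.

For compound 4 the step of a 2.9-fold higher number from compound 3 to compound 4 (0.46 log units; beyond the scatter) is expected, smaller than the earlier one, because a 13-fold higher number from compound 1 to compound 2 (1.12 log units; beyond the scatter) was measured on a starting point far lower than compound 3, and compound 3 already sits at a high number where further rises may be cut short by the range of the assay. Compound 4 is estimated at 110000 nM, with a range from 40000 nM to 400000 nM, and a real chance that only a limit is reported.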

Compound 4, half-maximal inhibitory concentration: "not active" (no number reported)
No number was reported for compound 4; no gap can be computed for the estimate.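

In this assay, going by these compounds alone, compound 4 is reported as "not active" without a number, and no step from compound 3 to compound 4 can be read. Nothing available bears on this result. The compounds shown leave open how large the change to 4-cyanophenyl is on the core of compound 3, compared with the core of compound 1.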